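Same Atoms, One Stereocentre Drawn: Compound 2 to Compound 3

This account rests on a few compounds, and the source may have more. Where it says the series, first, only, none or still open, it means among the compounds named here.

Measured so far:
compound 1 `COC[C@H](COc1nc(N2CCCCC2)c2nc(OC[C@H](COC)OC)nc(N3CCCCC3)c2n1)OC`: 100%
compound 2 `OCC(O)COc1nc(N2CCCCC2)c2nc(OCC(O)CO)nc(N3CCCCC3)c2n1`: 32%

In a functional assay on L1210 cells (Mus musculus) for inhibition, read by thymidine incorporation, tested at 10 uM (on this read-out lower numbers stand for a weaker effect and higher numbers for a stronger effect at the one concentration tested), compound 1 gives 100%, while compound 2 gives 32%. Within the data shown here, compound 2 therefore stands lowest of the two numbers; its only neighbour is compound 1, whose number lies higher by a gap that exceeds the usual scatter of repeated measurements.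

Compound 3 `OCC(O)COc1nc(N2CCCCC2)c2nc(OC[C@H](O)CO)nc(N3CCCCC3)c2n1` has not yet been tested. It differs from compound 2 only in how the structure is drawn: the two compounds have the same atoms and bonds; at least one stereo element is drawn with a configuration in one of them and without one in the other: 1 of 2 stereo elements differ; a stereocentre at a saturated chain carbon is drawn without a configuration in compound 2 and R in compound 3. Among the measured compounds shown here, no pair of measured compounds differs in just one place, so no measured step is available to guide the size of this one. With the same atoms and bonds on both sides, a change beyond the scatter in this assay is not expected. The expected step is no change at the digits printed from compound 2 to compound 3 (within the scatter). Compound 3 is accordingly estimated to give about 32%, within a range from 15% to 55%.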

Compound 3, a percentage reported as inhibition, at one concentration (the size of the read-out at that concentration, not a potency): 32%
For compound 3 middle estimate and measured number coincide at the digits printed; the measured number falls inside the stated range.
By their numbers in this assay, from the lowest: compounds 2 and 3 (each within the scatter of the next); then compound 1.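

In this assay, among these compounds, this pair gives the only step so far between compounds that differ in one place, and the result is no change at the digits printed from compound 2 to compound 3 (within the scatter). At this saturated chain carbon, then, drawing the stereocentre as R rather than leaving it without a configuration goes with no visible shift in the read-out. The pair is separated by nothing more than the way this one centre is drawn: the fact that one of compounds 2 and 3 is drawn with a defined configuration and the other without, at the place where they differ

The compounds shown leave open how a centre drawn as S at this carbon would read, and whether fixing the second stereocentre on the other chain would matter. They also leave open what an amine in place of a hydroxyl on this chain, or a longer chain at the same place, would do in this assay.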